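The compounds below may be only part of what the source reports. "The series", "measured", "known", "first", "only" and "open" are said of these compounds alone.

Compound 1 `NC(=O)c1ccn(-c2cccc(OC(=O)NCCCCCCc3ccccc3)c2)c1` carries a six-carbon chain ending in a phenyl group on its amide-type nitrogen, and in an assay (brain) for inhibition of Fatty-acid amide hydrolase 1 (Mus musculus), with stated times of 20 min and 15 min (a higher number here means a weaker inhibitor, a lower number a stronger inhibitor), compound 1 gives 0.6 nM. Compound 2 `C#CCCCCCCCCCOC(=O)c1ccn(-c2cccc(OC(=O)NCCCC)c2)c1` instead has a butyl group on that nitrogen and a long chain ending in a triple bond on the oxygen next to a carbonyl group. In this assay compound 2 reaches only a limit, > 70 nM. Compound 3 `C#CCCCCCCCCCOC(=O)c1ccn(-c2cccc(OC(=O)NC3CCCCC3)c2)c1`, with cyclohexyl in place of butyl on the amide-type nitrogen, likewise reaches only a limit in this assay, > 10000 nM. The step from compound 2 to compound 3 is therefore a step that the two limits leave unreadable from compound 2 to compound 3. On the numbers shown compound 3 sits at the limit of > 10000 nM in this assay, at which 1 of the 3 values shown sits, the weaker of the two limits. Compound 4 `O=C(NC1CCCCC1)Oc1cccc(-n2ccc(C(=O)OCCCCCCc3ccccc3)c2)c1` differs from compound 3 by phenyl in place of pent-4-yn-1-yl on a saturated chain carbon, six bonds along the chain from an oxygen next to a carbonyl group. For the measured compounds named here, no measured step covers this exchange; the only measured step, from compound 2 to compound 3, concerns the amide-type nitrogen that compound 3 and compound 4 share, and its size cannot be read. Since compound 3 sits at the limit of > 10000 nM in this assay, at which 1 of the 3 values shown sits, compound 4 is expected to remain weak, with an estimated step of an at least 1.2-fold lower number from compound 3 to compound 4 (0.09 log units; that floor lies within the scatter) that should not go beyond the scatter. Compound 4 is estimated at 8000 nM, with a range from 1000 nM to 50000 nM.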

Compound 4, half-maximal inhibitory concentration: > 50000 nM
Compound 4 gave a limit, no number (the forecaster's own chance of this, stated with the estimate: 60%); middle value at least 6.2-fold (0.79 log units) from the limit.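

Compound 3 and compound 4 both give only limits in this assay, and the step between them cannot be read. The compounds shown leave open how large the effect of phenyl in place of pent-4-yn-1-yl is with cyclohexyl on the amide-type nitrogen, and whether that exchange would read differently with butyl there.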